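Phenyl to 4-fluorophenyl: the step to compound 4

The source may hold more compounds than are shown below. What is called first, only, known or untested is meant among the compounds shown, and "the series" means these compounds.

Measured in a functional assay on A549 cells (Homo sapiens) for cytotoxicity, read by MTT assay, with a stated time of 72 h (on this read-out higher numbers stand for weaker inhibition and lower numbers for stronger inhibition), so far:
compound 1 `CNC(=O)c1cc(Oc2ccc(NC(=O)c3cc(-c4ccc(C(F)(F)F)cc4)ncn3)cc2F)ccn1` gives > 100000 nM as a limit of the assay
compound 2 `CCc1ccc(-c2cc(C(=O)Nc3ccc(Oc4ccnc(C(=O)NC)c4)c(F)c3)ncn2)cc1` gives 3390 nM as a number
compound 3 `CNC(=O)c1cc(Oc2ccc(NC(=O)c3cc(-c4ccccc4)ncn3)cc2F)ccn1` gives 23200 nM as a number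

Compound 1 reports only a limit, > 100000 nM, and no number. Of the two numbers, compound 3 at 23200 nM is the higher, and compound 2 at 3390 nM is the lower.

Compound 4 `CNC(=O)c1cc(Oc2ccc(NC(=O)c3cc(-c4ccc(F)cc4)ncn3)cc2F)ccn1` differs from compound 3 by fluoro in place of hydrogen on an aromatic carbon, with fluoro in place of hydrogen on an aromatic carbon, para to a large group. Going by the values given here, three measured steps concern that same place, all beyond the scatter: an at least 4.3-fold lower number from compound 1 to compound 3 (0.63 log units; beyond the scatter), a 6.8-fold higher number from compound 2 to compound 3 (0.84 log units; beyond the scatter) and an at least 29-fold lower number from compound 1 to compound 2 (1.46 log units; beyond the scatter). Compound 1 lies on the high side of compound 3 and compound 2 on the low side, so these steps set no direction for fluoro, which none of them involves. Only a small step, probably within the scatter, is therefore expected in this assay. The expected change is a 1.1-fold lower number from compound 3 to compound 4 (0.04 log units; within the scatter). Compound 4 is estimated at 21000 nM, with an expected range from 7000 nM to 70000 nM.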

Compound 4, half-maximal inhibitory concentration: > 100000 nM
Compound 4 was reported as a limit; the forecaster's own chance of this, stated with the estimate: 12%; at least 4.7-fold (0.67 log units) between middle value and limit.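

Placing fluoro on the phenyl ring moves the read-out in this assay beyond the scatter, with an at least 4.3-fold higher number from compound 3 to compound 4 (0.63 log units; beyond the scatter) and, against the ethyl group, an at least 29-fold higher number from compound 2 to compound 4 (1.46 log units; beyond the scatter). So far, the two compounds with fluorine on this ring, compound 1 and compound 4, give limits, while the two without it, compound 2 and compound 3, give numbers. Compound 4 gives a limit, shared with compound 1: the limit of > 100000 nM in this assay, at which 2 of the 4 values shown sit.

Going by these compounds, the two limits leave the step from compound 1 to compound 4 unreadable, so the order of fluoro and trifluoromethyl stays unknown. Also open, on these data alone, is whether a chloro, methoxy or amino group, or a chain longer than ethyl such as propyl, at this same place would give a number or a limit.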